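The source may report more compounds than this note shows. Statements on the series, on what has been measured and on what is new or still open speak of the compounds shown alone.

Compound 1 `O=S(=O)(Nc1ccc(F)c(C#Cc2cnc3[nH]ncc3c2)c1F)c1cccc(F)c1`: > 10000 nM
Compound 2 `O=S(=O)(Nc1ccc(F)c(C#Cc2cnc3[nH]ccc3c2)c1F)c1cccnc1`: > 10000 nM

Both entries come from a functional assay on HCT-116 cells (Homo sapiens) for antiproliferative activity, read by MTT assay, with a stated time of 68 h; a lower number here means a stronger inhibitor, a higher number a weaker inhibitor. Compound 2 gives > 10000 nM, which is a limit of the assay and not a number. Compound 1 gives > 10000 nM, which is also a limit. Neither compound therefore has an exact position on the scale, and the two cannot be ranked against each other.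

Compound 3 `O=S(=O)(Nc1ccc(F)c(C#Cc2cnc3ccnn3c2)c1F)c1cccnc1` differs from compound 2 in one place, the group on a triple-bonded carbon: a group of 9 heavy atoms (6 carbon, 3 nitrogen; one five-membered aromatic ring with 2 hetero atoms, one six-membered aromatic ring with 2 hetero atoms) in place of a group of 9 heavy atoms (7 carbon, 2 nitrogen; one five-membered aromatic ring with 1 hetero atom, one six-membered aromatic ring with 1 hetero atom), on a triple-bonded carbon.

Among the measured compounds shown here, no pair of measured compounds shows what a single change does in this assay, so the size of this step cannot be read from earlier data. The expectation rests on what has been seen so far: the limit of > 10000 nM in this assay, at which 2 of the 2 values shown sit. On that basis, no step beyond the scatter is expected, and the estimate is a step that the limit leaves unreadable from compound 2 to compound 3. A report of only a limit is the most likely outcome. For compound 3 the estimated value is 12000 nM, with an expected range from 4000 nM to 30000 nM.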

Compound 3, half-maximal inhibitory concentration: 10000 nM
Beside the measured number, compound 3's estimate is 1.2-fold (0.08 log units) above it; low and high end bracket the measured number.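

In this assay compound 3 gives 10000 nM, the only exact number among the compounds shown, so this change on the triple-bonded carbon gives the set its first fixed point on the scale. Compound 2 gives > 10000 nM, which is a limit of the assay and not a number. The size of the step between these two compounds therefore cannot be read, and the exchange of one nine-atom fused aromatic group for the other has not produced a clearly strong inhibitor, which fits the picture so far: the limit of > 10000 nM in this assay, at which 2 of the 3 values shown sit.

Whether the group on the triple-bonded carbon can influence activity in this assay at all stays open, since the data show a number no higher from compound 2 to compound 3 (the limit leaves the size open) and no compound shown gives a number well away from this end of the scale. Also open, on these data alone, is what would follow if a group carrying an amine or a carboxylic acid stood on the triple-bonded carbon in place of these nine-atom groups.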